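The compounds below may be only part of what the source reports. "The series", "measured", "known", "first", "only" and "open" are said of these compounds alone.

In a functional assay on SK-OV-3 cells (Homo sapiens) for cytotoxicity, read by sulforhodamine B assay, with a stated time of 48 h, tested at 100 nM (on this read-out lower numbers stand for a stronger effect and higher numbers for a weaker effect at the one concentration tested), compound 1 `COc1cc(C)cc(-c2c(-c3ccnc(-c4ccc(C(C)=O)cc4)c3)cnn2CC#N)c1` gives 102%, the highest of the three numbers shown. Compound 3 `Cc1cc(O)cc(-c2nn(CC#N)cc2-c2ccnc(-c3ccc(N(C)C)cc3)c2)c1` gives 101%, a number within the scatter of compound 1, while compound 2 `COc1cc(C)cc(-c2nn(CC#N)cc2-c2ccnc(-c3ccc(N(C)C)cc3)c2)c1` gives -6%, far below both. Among the measured compounds shown here, the only one-place step measured, a number 107 percentage points higher from compound 2 to compound 3 (beyond the scatter), concerns a methoxy group turned into a hydroxyl and says nothing about the change now at hand.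

Compound 4 `COc1cc(C)cc(-c2c(-c3ccnc(-c4ccc(N(C)C)cc4)c3)cnn2CC#N)c1` differs from compound 1 in one place: dimethylamino in place of acetyl on an aromatic carbon. For the measured compounds named here, no measured step describes this exchange directly. Going by the values given here, the one hint comes from compound 2, which carries the same dimethylamino group on a differently arranged core and gives -6%. That hint points toward a lower number, so a step downward beyond the scatter is expected, a number 62 percentage points lower from compound 1 to compound 4 (beyond the scatter), though its size is uncertain without a direct comparison. For compound 4 the estimate in this assay is therefore 40%, with a range from -10% to 100%.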

Compound 4, a percentage reported as activity, at one concentration (the size of the read-out at that concentration, not a potency): 37%
For compound 4 the middle estimate is 3 percentage points above the measured one; the measured number falls inside the stated range.
By their numbers in this assay, from the lowest: compound 2; then compound 4; then compounds 3 and 1 (each within the scatter of the next).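

In this assay, the exchange on this aromatic carbon, para to a large group, gives a number 65 percentage points lower from compound 1 to compound 4 (beyond the scatter), the first sign that the group held at this place matters on the core of compound 1. The step is large even though acetyl and dimethylamino match in heavy atoms and in hydrogen-bond acceptors, so those counts alone do not tell these two groups apart. No measurement shown here explains why the exchange has this effect.

Still open, as far as these compounds go, is where other groups at this place, such as a carboxylic acid, a primary amine or a longer chain ending in an amine, would fall relative to compound 1 and compound 4. Also open, from the compounds shown here alone, is whether a hydroxyl in place of the methoxy group would change the number for compound 4.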